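The compounds below may be only part of what the source reports. "The series", "measured", "known", "first", "only" and "open" are said of these compounds alone.

Compound 1, `Cc1ccc2oc(-c3cc4ccccc4s3)cc(=O)c2c1`, was tested in an ADME assay on THP-1 cells (Homo sapiens) for inhibition, read by MTT assay, with a stated time of 72 h; a lower number here means a stronger inhibitor of growth, a higher number a weaker inhibitor of growth. In this assay compound 1 gives > 100 ug/mL, which is a limit of the assay and not a number. Compound 2, `Cc1cc(O)c(C(=O)CC(=O)c2cc3ccccc3s2)cc1Cl`, was tested in the same way. In this assay compound 2 gives > 100 ug/mL, which is again a limit rather than a number. Among the measured compounds shown here, compound 2 therefore stands only at a limit, and the one other value shown is a limit as well, as the limit of > 100 ug/mL in this assay, at which 2 of the 2 values shown sit, states. Compound 3, `Cc1ccc(C(=O)CC(=O)c2cc3ccccc3s2)c(O)c1`, has not yet been measured. It differs from compound 2 in a single place: hydrogen in place of chloro on an aromatic carbon. For the measured compounds named here, no measured pair shows what such a change does to growth inhibition here. The step expected in this assay is a step that the limit leaves unreadable from compound 2 to compound 3, meaning no step beyond the usual scatter. Compound 3 is thus expected to give about 150 ug/mL in this assay, estimated to fall between 60 ug/mL and 400 ug/mL.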

Compound 3, concentration for 50% growth inhibition: > 100 ug/mL
Compound 3 was reported as a limit (the forecaster's own chance of this, stated with the estimate: 80%); the middle value lies beyond the limit too.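

No step can be read from compound 2 to compound 3, because both values are limits of the assay and not numbers: the limit of > 100 ug/mL in this assay, at which 3 of the 3 values shown sit.

The compounds shown leave open how strongly any of them inhibits growth, and whether hydrogen in place of chloro changes that inhibition at all.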